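Chloro to amino on a fused core in a kinase assay

The source may report more compounds than this note shows. Statements on the series, on what has been measured and on what is new or still open speak of the compounds shown alone.

Of the compounds shown here, three have been measured in an assay on isolated protein for inhibition of Rho-associated protein kinase 1 (Homo sapiens), tested at 30 uM; on this read-out higher numbers stand for more inhibition at the one concentration tested (going by the name of the read-out) and lower numbers for less inhibition. Compound 1 `Fc1ccc(-[n+]2c[nH]c3ncncc32)cc1` gives 2%. Compound 2 `Clc1ncnc2c1ncn2Cc1ccccc1` gives 3%. Within the data shown here, compound 3 `Fc1ccc(Cn2cnc3c(Cl)ncnc32)cc1` gives 0%, a number that sits alongside those of compound 1 and compound 2, since the only tabulated step, a number 3 percentage points lower from compound 2 to compound 3 (within the scatter), stays within the scatter, and the gap to compound 1 does so too.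

Compound 4 `Nc1ncnc2c1ncn2Cc1ccc(F)cc1` differs from compound 3 by amino in place of chloro on an aromatic carbon. Among the measured compounds shown here, no measured step exchanges chloro for amino; the one step available, a number 3 percentage points lower from compound 2 to compound 3 (within the scatter), concerns a different change and was itself within the scatter, so it offers no direction for this one. All three measured numbers lie close to the floor of the read-out, and nothing among them suggests that compound 4 would move away from it. Compound 4 is therefore expected to stay near compound 3, with an estimated step of a number 3 percentage points higher from compound 3 to compound 4 (within the scatter), at an estimated value of 3%, within a range of 0% to 14%.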

Compound 4, a percentage reported as inhibition, at one concentration (the size of the read-out at that concentration, not a potency): 0%
The estimate for compound 4 lay 3 percentage points above the measured number; measured number inside the range.
By their numbers in this assay, from the lowest: compounds 3, 4, 1 and 2 (each within the scatter of the next).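

In this assay, amino in place of chloro on the aromatic carbon next to the ring nitrogen gives no change at the digits printed from compound 3 to compound 4 (within the scatter). Among these compounds, the only earlier step concerned fluoro in place of hydrogen, so this is the first reading at this position, and it shows that exchanging chloro for amino, which adds a hydrogen-bond donor and a hydrogen-bond acceptor, leaves the number at the floor of the read-out. No measurement at hand offers an explanation for this result.

With every number this close to the floor, the compounds shown cannot say whether this position has any bearing on inhibition. On these data alone, whether a longer chain on the amine, such as a butylamine, or a carboxylic acid at this place would move the shared core beyond the scatter stays open.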